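Compound 3 to compound 4: chloro replaces fluoro

The source may report more compounds than this note shows. Statements on the series, on what has been measured and on what is new or still open speak of the compounds shown alone.

Compound 1 `Brc1ccccc1CSc1nnc(-c2cnccn2)o1` gives 8890 nM
Compound 2 `Fc1ccccc1CSc1nnc(-c2cnccn2)s1` gives 32700 nM
Compound 3 `Fc1ccc(CSc2nnc(-c3cnccn3)s2)cc1` gives > 50000 nM

All three results come from a functional assay on HeLa cells (Homo sapiens) for antiproliferative activity, read by MTT assay, with a stated time of 48 h; on this read-out higher numbers stand for weaker inhibition and lower numbers for stronger inhibition. Compound 3 stands at a limit of the assay, so its entry > 50000 nM is a limit and not a number.

Compound 4 `Clc1ccc(CSc2nnc(-c3cnccn3)s2)cc1` keeps the shared core of compound 3 and changes a single substituent: chloro in place of fluoro on an aromatic carbon, para to a large group (chloro in place of fluoro on an aromatic carbon).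

Going by the values given here, no measured pair shows this swap alone, and compound 3 offers no exact number, so the size of the step cannot be read directly from the data. In this assay the expectation is a small shift toward stronger inhibition, possibly none beyond the usual scatter. This expectation leaves compound 4 near the value of compound 2 (32700 nM) and well short of the value of compound 1 (8890 nM). The expected move, a rough estimate, is an at least 1.5-fold lower number from compound 3 to compound 4 (0.19 log units; that floor lies within the scatter) (measured against a limit). The expected value for compound 4 is 32000 nM (estimated range 12000 nM to 60000 nM).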

Compound 4, half-maximal inhibitory concentration: 18900 nM
Compound 4: the middle estimate sits 1.7-fold (0.23 log units) above what was measured; low and high end bracket the measured number.
By their numbers in this assay, from the lowest: compound 1; then compounds 4 and 2 (each within the scatter of the next). At a limit, above all of these: compound 3.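

In this assay, compound 3 carries fluoro on an aromatic carbon para to a large group, and its entry of > 50000 nM is a limit of the assay and not a number. Chloro at that same place gives a measured value, and the step is an at least 2.6-fold lower number from compound 3 to compound 4 (0.42 log units; beyond the scatter), so this position does respond to which halogen it carries, even though one heavy atom simply replaces another and no hydrogen-bond donor, hydrogen-bond acceptor or net charge enters or leaves. That size is only a floor, since the true number for compound 3 lies out of reach of the assay: the limit of > 50000 nM in this assay, at which 1 of the 4 values shown sits.

The compounds shown leave open whether a different group at this place, such as a methoxy group, an amine or a carboxylic acid, would lower the number further or raise it again. They also leave open whether the swap from fluoro to chloro would have a similar effect at another place on the same six-membered ring.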